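Trifluoromethyl to Fluoro on the Benzyl Ether of Compound 3

The source may report more compounds than this note shows. Statements on the series, on what has been measured and on what is new or still open speak of the compounds shown alone.

Compound 1 `Cc1ccc(NC(=S)NC(=O)c2ccc(OCc3ccc(C(F)(F)F)cc3)cc2)cc1-c1nc2ccccc2[nH]1`: 72400 nM
Compound 2 `Cc1ccc(NC(=S)NC(=O)c2ccc(OCc3ccccc3F)cc2)cc1-c1nc2ccccc2[nH]1`: 6440 nM
Compound 3 `Cc1ccc(NC(=O)NC(=O)c2ccc(OCc3ccc(C(F)(F)F)cc3)cc2)cc1-c1nc2ccccc2[nH]1`: 15300 nM

Of the compounds shown here, three sharing one core have been measured in a functional assay on SW-620 cells (Homo sapiens) for inhibition, read by MTT assay, with a stated time of 48 h; on this read-out higher numbers stand for weaker inhibition and lower numbers for stronger inhibition. Compound 3 gives the second highest of the three numbers; compound 2 lies nearest, with a lower number, and compound 1 furthest, with a higher one. Compound 4 `Cc1ccc(NC(=O)NC(=O)c2ccc(OCc3ccc(F)cc3)cc2)cc1-c1nc2ccccc2[nH]1` differs from compound 3 by fluoro in place of trifluoromethyl on an aromatic carbon. Among the compounds with values here, the one measured step that bears on this is an 11-fold lower number from compound 1 to compound 2 (1.05 log units; beyond the scatter), where trading the trifluoromethyl-bearing benzyl for a fluorine-bearing one brought a large fall. That change is not identical to the present one, so a more modest step is expected here, estimated as a 3.4-fold lower number from compound 3 to compound 4 (0.53 log units; beyond the scatter). Compound 4 is therefore expected to give about 4500 nM, between 1500 nM and 13000 nM.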

Compound 4, half-maximal inhibitory concentration: 35100 nM
Estimate against measurement, compound 4: 7.8-fold (0.89 log units) below; measured number above the stated range.
By their numbers in this assay, from the lowest: compound 2; then compound 3; then compound 4; then compound 1.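

In this assay, fluoro in place of trifluoromethyl on this aromatic carbon gives a 2.3-fold higher number from compound 3 to compound 4 (0.36 log units; beyond the scatter), so inhibition weakens with the smaller group. The earlier fall of an 11-fold lower number from compound 1 to compound 2 (1.05 log units; beyond the scatter) therefore does not carry over to a fluorine at this position on the carbonyl compounds, though that step also differed in where the fluorine sits and came with sulfur in place of the carbonyl oxygen. No measurement here speaks to the cause of this rise. Still open, going by these compounds, is how a chloro or methoxy group would read on this carbon, and how the 2-fluorophenyl group would read on the core of compound 3.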